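The compounds below may be only part of what the source reports. "The series", "measured", "known", "first", "only" and "open" are said of these compounds alone.

Compound 1 `O=C(NCc1cc(-c2ccc(C(F)(F)F)nc2)ncn1)[C@@H]1CCCN1S(=O)(=O)c1ccc(F)cc1`: 2.7
Compound 2 `C[C@H]1CC[C@@H](C(=O)NCc2cc(-c3ccc(C(F)(F)F)nc3)ncn2)N1S(=O)(=O)c1ccc(F)cc1`: 2.9

In a physicochemical assay for lipophilicity, at pH 7.4 (on this read-out lower numbers stand for lower lipophilicity and higher numbers for higher lipophilicity), compound 2 gives 2.9, which lies within the scatter of compound 1 at 2.7. The next compound, compound 3 `C[C@@H]1CC[C@@H](C(=O)NCc2cc(-c3ccc(C(F)(F)F)nc3)ncn2)N1S(=O)(=O)c1ccc(F)cc1`, departs from compound 2 in one way: the two compounds have the same atoms and bonds and differ only in configuration as drawn: 1 of 2 stereo elements differ; a stereocentre at a saturated ring carbon is drawn S in compound 2 and R in compound 3. The two share the same atoms and bonds, and a stereocentre at a saturated ring carbon is drawn S in compound 2 and R in compound 3. Among the measured compounds shown here, only one measured step lies nearby, a number 0.20 log units higher from compound 1 to compound 2 (within the scatter), and it places a methyl in place of hydrogen on a saturated ring carbon. That step stayed within the scatter, but it changes an atom and not a configuration, so it bears on the question only indirectly. For the measured compounds named here, no measured pair shows what a change of configuration does in this assay. The expected step is no change at the digits printed from compound 2 to compound 3 (within the scatter), so no change beyond the scatter is anticipated. Compound 3 is estimated at 2.9, with an expected range of 2.6 to 3.2.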

Compound 3, distribution coefficient: 4.3
The estimate for compound 3 lay 1.40 log units below the measured number; measured number outside the range, above it.
By their numbers in this assay, from the lowest: compounds 1 and 2 (each within the scatter of the next); then compound 3.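

In this assay the result shows a number 1.40 log units higher from compound 2 to compound 3 (beyond the scatter), and this step belongs to the stereocentre at a saturated ring carbon alone, because nothing else separates the pair: the fact that compounds 2 and 3 differ only in the configuration as drawn. The same methyl in place of hydrogen on a saturated ring carbon, which stayed within the scatter in a number 0.20 log units higher from compound 1 to compound 2 (within the scatter), gives a number 1.60 log units higher from compound 1 to compound 3 (beyond the scatter) in its other drawn configuration. At this position, then, what the methyl does to the read-out depends on its configuration, which the earlier pair could not show.

The compounds shown leave open what lies behind so large a step and whether changing the other stereocentre would matter as much. They also leave open whether an ethyl or a hydroxymethyl group on this ring carbon would depend on configuration in the same way.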